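One added methyl and compound 4

A few compounds are considered here, and "the series" means these few. Any claim that something is new, unique, unknown or untested is made for them only; others in the source may bear on it.

Measured in a physicochemical assay for solubility, read by HPLC, in phosphate buffer, at pH 6.8; on this read-out higher numbers stand for higher solubility and lower numbers for lower solubility:
compound 1 `CC(=O)N1CCN(C(=O)[C@@H]2CC[C@@H](C)N2C(=O)C2=C(C(C)C)N3C(=N[C@@](C)(c4ccc(Cl)cc4)[C@H]3c3ccc(Cl)cc3)S2)CC1`: 79 ug/mL
compound 2 `CC[C@@H]1CC[C@@H](C(=O)N2CCN(C(C)=O)CC2)N1C(=O)C1=C(C(C)C)N2C(=N[C@@](C)(c3ccc(Cl)cc3)[C@H]2c2ccc(Cl)cc2)S1`: 34 ug/mL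
compound 3 `CC[C@@H]1CC[C@@H](C(=O)N2CCOCC2)N1C(=O)C1=C(C(C)C)N2C(=N[C@@](C)(c3ccc(Cl)cc3)[C@H]2c2ccc(Cl)cc2)S1`: 9 ug/mL

Compound 1 stands highest of these three. Compound 4 `CC(=O)N1CCN(C(=O)[C@@H]2CC[C@@H](C)N2C(=O)C2=C(C(C)C)N3C(=N[C@@](C)(c4ccc(Cl)cc4)[C@H]3c3ccc(Cl)cc3)S2)C[C@@H]1C` differs from it by methyl in place of hydrogen on a saturated ring carbon, (methyl in place of hydrogen on a saturated ring carbon). Among the compounds with values here, the nearest precedent is a 2.3-fold lower number from compound 1 to compound 2 (0.37 log units; beyond the scatter), also a methyl for a hydrogen, though on a saturated chain carbon. The other measured step, a 3.8-fold lower number from compound 2 to compound 3 (0.58 log units; beyond the scatter), removes the 4-acetylpiperazin-1-yl group that carries the new methyl, so it bears only loosely. On the precedent of compound 2 at 34 ug/mL, a modest fall in this assay is expected, possibly staying within the scatter. The expected change is a 1.5-fold lower number from compound 1 to compound 4 (0.18 log units; within the scatter). Compound 4 is estimated at 52 ug/mL, with an expected range of 22 ug/mL to 120 ug/mL.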

Compound 4, solubility: 75 ug/mL
For compound 4 the middle estimate is 1.4-fold (0.16 log units) below the measured one, and the stated range covers the measured number.
By their numbers in this assay, from the lowest: compound 3; then compound 2; then compounds 4 and 1 (each within the scatter of the next).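

In this assay, methyl in place of hydrogen on a saturated ring carbon of the six-membered non-aromatic ring with 2 nitrogen gives a 1.1-fold lower number from compound 1 to compound 4 (0.02 log units; within the scatter), whereas the same exchange on a saturated chain carbon gave a 2.3-fold lower number from compound 1 to compound 2 (0.37 log units; beyond the scatter). A methyl for a hydrogen therefore does not shift this read-out equally at both places. No available evidence bears on why the two places differ.

The compounds shown leave open how the opposite configuration of this methyl would read. They also leave open whether an ethyl, a hydroxymethyl or an amine on this ring carbon would match the methyl.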